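Nitro on the aromatic ring of compound 1

A few compounds are considered here, and "the series" means these few. Any claim that something is new, unique, unknown or untested is made for them only; others in the source may bear on it.

In a functional assay on KB cells (Homo sapiens) for antiproliferative activity, read by sulforhodamine B assay, with a stated time of 72 h (on this read-out lower numbers stand for stronger inhibition and higher numbers for weaker inhibition), compound 1 `COc1ccc(/C=C2\CCC=CC2=O)cc1` gives 1560 nM. Compound 3 `COc1ccc(/C=C2\CCC=CC2=O)c(C)c1` gives 1310 nM, level with compound 1 within the scatter. Compound 2 `O=C1C=CCC/C1=C\c1ccc(OC(F)(F)F)cc1` gives 530 nM and is the only one of the three clearly apart.

Compound 4 `COc1ccc(/C=C2\CCC=CC2=O)cc1[N+](=O)[O-]` carries a single change from compound 1, nitro in place of hydrogen on an aromatic carbon, ortho to a methoxy group: nitro in place of hydrogen on an aromatic carbon.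

For the measured compounds named here, two measured steps bear on it. The nearer in kind is a 1.2-fold lower number from compound 1 to compound 3 (0.08 log units; within the scatter), also a replacement of hydrogen on an aromatic carbon, but by methyl. The other is a 2.9-fold lower number from compound 1 to compound 2 (0.47 log units; beyond the scatter), a modest step with trifluoromethyl in place of methyl on an oxygen. Neither step involves nitro, so the precedent is indirect, and neither goes to a higher number.

The expected step in this assay is a 1.6-fold lower number from compound 1 to compound 4 (0.19 log units; within the scatter), leaning to a lower number without clearing the scatter. For compound 4 the estimate is 1000 nM, with an expected range of 400 nM to 2300 nM.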

Compound 4, half-maximal inhibitory concentration: 1360 nM
Compound 4: the middle estimate sits 1.4-fold (0.13 log units) below what was measured, and the stated range covers the measured number.
By their numbers in this assay, from the lowest: compound 2; then compounds 3, 4 and 1 (each within the scatter of the next).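

In this assay, nitro in place of hydrogen on an aromatic carbon, ortho to a methoxy group, gives a 1.1-fold lower number from compound 1 to compound 4 (0.06 log units; within the scatter) and so leaves the number level with compound 1, even though the entering group has 3 heavy atoms and 2 hydrogen-bond acceptors. Together with methyl in compound 3, this makes two replacements of hydrogen on an aromatic carbon that stay within the scatter of compound 1, while the only step from compound 1 beyond the scatter remains the change on the oxygen in compound 2. No measurement shown here bears on why the nitro replacement leaves the number level.

From the compounds shown here alone, whether an amine or a carboxylic acid on this same carbon would also stay level with compound 1 remains open. Also open, going by these compounds, is whether nitro here would alter the step seen with trifluoromethyl on the oxygen.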